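This account rests on a few compounds, and the source may have more. Where it says the series, first, only, none or still open, it means among the compounds named here.

Working notes on the series. Among the measured compounds shown here, in a functional assay on HEK293 cells for agonist activity at D(4) dopamine receptor (Homo sapiens), read by FLIPR (on this read-out lower numbers stand for smaller maximal responses and higher numbers for larger maximal responses), compound 1 `Cc1cccc(NC(=O)CN2CCC(c3cccc(F)c3)CC2)c1` gives 40% and compound 2 `Cc1cccc(NC(=O)CN2CCC(c3cccc(O)c3)CC2)c1` gives 66%, the higher of the two numbers; the one measured step, a number 26 percentage points higher from compound 1 to compound 2 (beyond the scatter), is the only guide available. Compound 3 `Cc1cccc(NC(=O)CN2CCC(c3cccc(C#N)n3)CC2)c1` differs from compound 2 by 6-cyanopyridin-2-yl in place of 3-hydroxyphenyl on a saturated ring carbon. Because a number 26 percentage points higher from compound 1 to compound 2 (beyond the scatter) was gained on introducing the hydroxy, and compound 3 gives up the hydroxy for a group without a donor, a downward step is expected, a number 21 percentage points lower from compound 2 to compound 3 (beyond the scatter), of roughly the same size. Compound 3 is therefore estimated at 45% in this assay, within 22% to 70%.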

Compound 3, largest response reached (reported as efficacy), in percent of the reference or control that the assay uses: 42%
Beside the measured number, compound 3's estimate is 3 percentage points above it; low and high end bracket the measured number.
By their numbers in this assay, from the lowest: compounds 1 and 3 (each within the scatter of the next); then compound 2.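

In this assay, 6-cyanopyridin-2-yl in place of 3-hydroxyphenyl gives a number 24 percentage points lower from compound 2 to compound 3 (beyond the scatter) and so takes back most of the gain seen with the hydroxy. Set against 3-fluorophenyl, the same group gives a number 2 percentage points higher from compound 1 to compound 3 (within the scatter) and so cannot be told apart from it; of the three groups at this saturated ring carbon, only 3-hydroxyphenyl stands apart. No available evidence accounts for these steps.

As far as these compounds go, whether 3-aminophenyl here would respond like compound 2 or like compound 3 stays open. So does the effect of a carboxylic acid in place of the nitrile.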